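Swapping the Methoxyphenyl Ring for a Chlorophenyl Ring

The source may report more compounds than this note shows. Statements on the series, on what has been measured and on what is new or still open speak of the compounds shown alone.

Compound 2 `COc1cccc(/C=C2\CCC/C(=C\c3ccc([N+](=O)[O-])cc3)C2=O)c1` gives 11.5 ug/mL in a functional assay on SK-N-MC cells (Homo sapiens) for cytotoxicity, read by MTT assay; on this read-out higher numbers stand for weaker inhibition and lower numbers for stronger inhibition. Among the three measured compounds it stands second highest, with compound 1 `COc1cccc(/C=C2\CCC/C(=C\c3cccc([N+](=O)[O-])c3)C2=O)c1OC` nearest at 10.1 ug/mL and compound 3 `COc1cccc(/C=C2\CCC/C(=C\c3ccc([N+](=O)[O-])cc3)C2=O)c1OC` furthest at 22.2 ug/mL; both gaps lie within the scatter. Compound 4 `O=C1/C(=C/c2ccc(Cl)cc2)CCC/C1=C\c1ccc([N+](=O)[O-])cc1` differs from compound 2 by 4-chlorophenyl in place of 3-methoxyphenyl on a double-bonded chain carbon bound to a double-bonded ring carbon. Within the data shown here, no measured step swaps one whole aryl ring for another. The step of a 2.2-fold higher number from compound 1 to compound 3 (0.34 log units; beyond the scatter) concerns the other ring, while the closest guide is a 1.9-fold higher number from compound 2 to compound 3 (0.29 log units; within the scatter), which touched the same ring and stayed within the scatter, so no step beyond the scatter is expected in this assay. Compound 4 is therefore estimated at 12 ug/mL, between 5 ug/mL and 30 ug/mL, an expected step of a 1.0-fold higher number from compound 2 to compound 4 (0.02 log units; within the scatter).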

Compound 4, half-maximal inhibitory concentration: 14.1 ug/mL
For compound 4 the middle estimate is 1.2-fold (0.07 log units) below the measured one, and the stated range covers the measured number.
By their numbers in this assay, from the lowest: compounds 1, 2, 4 and 3 (each within the scatter of the next, the first and the last beyond it).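

In this assay the exchange of 3-methoxyphenyl for 4-chlorophenyl gives a 1.2-fold higher number from compound 2 to compound 4 (0.09 log units; within the scatter) and so shows that, for this pair, a whole aryl ring on this carbon can change without a step beyond the scatter. Among these compounds, the earlier steps changed only one group on a ring or the place of the nitro group. Nothing measured here explains this result. Still open, on these data alone, is whether an amine or a carboxylic acid in place of the chlorine would stay within the scatter, and whether a longer chain between this carbon and the ring would.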